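This account rests on a few compounds, and the source may have more. Where it says the series, first, only, none or still open, it means among the compounds named here.

Compound 1 `COc1ccc(F)cc1N1C(=O)CSC1c1cccc(C(=O)NCCCCc2ccccc2)c1` has the higher of the two numbers measured in a functional assay on HOS cells (Homo sapiens) for inhibition, read by CCK-8 assay, with a stated time of 72 h, tested at 1 uM (on this read-out higher numbers stand for more inhibition at the one concentration tested (going by the name of the read-out) and lower numbers for less inhibition), giving 46%. Compound 2 `COc1ccccc1N1C(=O)CSC1c1cc(F)cc(C(=O)O)c1` sits well apart: in this assay compound 2 gives 8%, a gap beyond the usual scatter. Compound 3 `COc1ccc(N2C(=O)CSC2c2cccc(C(=O)NCCCCc3ccccc3)c2)c(OC)c1` has not been measured. It differs from compound 1 by 2,4-dimethoxyphenyl in place of 5-fluoro-2-methoxyphenyl on an amide-type nitrogen in a ring. Among the measured compounds shown here, no step between measured compounds is available to guide this change, so only a modest shift, with no firm direction, is expected: the step from compound 1 to compound 3 is estimated as a number 6 percentage points lower from compound 1 to compound 3 (within the scatter). Compound 3 is therefore expected to give about 40% in this assay, within 20% to 60%.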

Compound 3, a percentage reported as inhibition, at one concentration (the size of the read-out at that concentration, not a potency): 82%
Compound 3: middle estimate off by 42 percentage points, on the low side; the whole stated range lies below it.
By their numbers in this assay, from the lowest: compound 2; then compound 1; then compound 3.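

In this assay, replacing 5-fluoro-2-methoxyphenyl with 2,4-dimethoxyphenyl on the amide-type nitrogen in the ring gives a number 36 percentage points higher from compound 1 to compound 3 (beyond the scatter). The earlier compounds shown here offered no step at this position, and this one shows that the read-out is sensitive to the group placed there while the rest of compound 1 stays unchanged. Nothing available accounts for the gain. The compounds shown leave open whether it follows the loss of the fluorine or the arrival of the second methoxy group. As far as these compounds go, how an amine or a nitrile on this ring would read also remains open.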